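Swapping a dihydroxyphenyl for a nitrophenyl on a shared hydrazone core

The source may report more compounds than this note shows. Statements on the series, on what has been measured and on what is new or still open speak of the compounds shown alone.

Three compounds with a common core have been examined in a physicochemical assay for lipophilicity, measured as octanol-water partition; a higher number here means a more lipophilic compound, a lower number a more polar compound. Compound 1 `O=C(COc1cccc2ccccc12)N/N=C/c1ccccc1Br` gives 4.81. Compound 2 `C/C(=N\NC(=O)COc1cccc2ccccc12)c1ccc(O)cc1O` gives 4.31. Compound 3 `O=C(COc1cccc2ccccc12)N/N=C/c1ccc([N+](=O)[O-])cc1` gives 3.97. Among these three, compound 2 stands second highest: it sits a little above compound 3, by a gap beyond the scatter, and a larger gap below compound 1, also beyond the scatter.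

Compound 4 `C/C(=N\NC(=O)COc1cccc2ccccc12)c1ccc([N+](=O)[O-])cc1` has not yet been measured in this assay. It differs from compound 2 in one place: 4-nitrophenyl in place of 2,4-dihydroxyphenyl on a carbon with a double bond to nitrogen.

Going by the values given here, no measured pair here shows exactly this change, so the expectation rests on the surrounding numbers. Compound 3 carries the same 4-nitrophenyl group and gives 3.97, and compound 2 already lies close to it. The step from compound 2 to compound 4 is therefore expected to be small, roughly a number 0.09 log units higher from compound 2 to compound 4 (within the scatter), and may well fall within the scatter. For compound 4 the estimated value in this assay is 4.4, with a range from 3.9 to 4.9.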

Compound 4, partition coefficient: 3.37
Compound 4: the middle estimate sits 1.03 log units above what was measured, and the stated range ends above it.
By their numbers in this assay, from the lowest: compound 4; then compound 3; then compound 2; then compound 1.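

In this assay, putting 4-nitrophenyl in place of 2,4-dihydroxyphenyl on a carbon with a double bond to nitrogen gives a number 0.94 log units lower from compound 2 to compound 4 (beyond the scatter), so the group at this position clearly matters for this reading. The group that leaves has 2 hydrogen-bond donors and the group that enters has 0, yet the compound without donors gives the lower number, so the donor count alone does not order this pair. Nothing measured here explains the size of this step.

The step also replaces the hydroxyl groups and brings in the nitro group at once, which leaves the contribution of each unresolved. Going by these compounds, how a plain phenyl, or a phenyl carrying an amine or a carboxylic acid, would read at this position remains open.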